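Swapping the aryl group on compound 1

The source may hold more compounds than are shown below. What is called first, only, known or untested is meant among the compounds shown, and "the series" means these compounds.

Compound 1 `COc1cc(N(CC(C)C)c2cccc(C(F)(F)F)c2)cnc1C(=O)[C@H]1C[C@@H]1C(=O)O` gives 4.74 nM in an assay for inhibition of leukotriene C4 synthase (Homo sapiens), read by LC-MS, with stated times of 15 min and 30 min; a lower number here means a stronger inhibitor, a higher number a weaker inhibitor.
Compound 2 `CCN(c1cccc(C(F)(F)F)c1)c1cnc(C(=O)[C@H]2C[C@@H]2C(=O)O)c(OC)c1` gives 13 nM in this assay.

Compound 1 stands at the lower of the two numbers; its nearest neighbour is compound 2, with a 2.7-fold higher number from compound 1 to compound 2 (0.44 log units; beyond the scatter). Compound 3 `COc1cc(N(CC(C)C)c2cc(Cl)c(F)cc2F)cnc1C(=O)[C@H]1C[C@@H]1C(=O)O` differs from compound 1 by 5-chloro-2,4-difluorophenyl in place of 3-(trifluoromethyl)phenyl on a nitrogen on an aromatic ring. Among the compounds with values here, no measured step changes that aryl group; the one measured step alters only the chain on the nitrogen. Without a comparable step, the expected change is small, within the scatter, so the step of a 1.7-fold higher number from compound 1 to compound 3 (0.23 log units; within the scatter) is estimated as roughly neutral. Compound 3 is therefore expected to give about 8 nM, within a range of 2 nM to 35 nM.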

Compound 3, half-maximal inhibitory concentration: 0.7 nM
Compound 3: the middle estimate sits 11-fold (1.06 log units) above what was measured, outside the stated range (below it).
By their numbers in this assay, from the lowest: compound 3; then compound 1; then compound 2.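

The aryl group on this nitrogen clearly matters: 5-chloro-2,4-difluorophenyl in place of 3-(trifluoromethyl)phenyl gives a 6.8-fold lower number from compound 1 to compound 3 (0.83 log units; beyond the scatter) in this assay. Both groups are a single six-membered aromatic ring of carbon, so the change lies only in the atoms carried on that ring. Nothing measured here gives a reason for this drop. On these data alone, the chlorine and the two fluorines arrive together, so the share of each remains unknown. Also open, as far as these compounds go, is whether a nitrile or an amine on that ring would keep the number this low.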